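Hydroxy to methoxy on the shared core, one step forward

A few compounds are considered here, and "the series" means these few. Any claim that something is new, unique, unknown or untested is made for them only; others in the source may bear on it.

Of the compounds shown here, three built on one shared core have been tested. Compound 1 `COc1cc(Cl)cc(-c2nn(-c3cccc(NC(=O)c4ccc(Cl)c(Cl)c4)c3)cc2-c2ccncc2)c1` and compound 2 `COc1cc(Cl)cc(-c2nn(-c3cccc(NC(=O)c4cccc(C(F)(F)F)c4)c3)cc2-c2ccncc2)c1` carry a methoxy group on the chlorinated phenyl ring, while compound 3 `O=C(Nc1cccc(-n2cc(-c3ccncc3)c(-c3cc(O)cc(Cl)c3)n2)c1)c1cc(C(F)(F)F)cc(C(F)(F)F)c1` carries a hydroxy group there instead. In a functional assay on UO-31 cells (Homo sapiens) for inhibition, read by sulforhodamine B assay, with a stated time of 48 h, tested at 10 uM (a lower number here means a stronger effect, a higher number a weaker effect of the compound at the concentration tested), compound 3 gives 49.2%. Compound 1 gives 43.5% in this assay, a gap that lies within the usual scatter, whereas compound 2 gives 37.3%, a gap that lies beyond it. Compound 4 `COc1cc(Cl)cc(-c2nn(-c3cccc(NC(=O)c4cc(C(F)(F)F)cc(C(F)(F)F)c4)c3)cc2-c2ccncc2)c1` is the next compound, and it differs from compound 3 in one place: methyl in place of hydrogen on an oxygen on an aromatic ring This turns 3-chloro-5-hydroxyphenyl into 3-chloro-5-methoxyphenyl. For the measured compounds named here, the only measured step, a number 6.2 percentage points lower from compound 1 to compound 2 (within the scatter), concerns the amide part and not this oxygen, so no measured step bears directly on the change. With nothing to suggest a shift, the expected step of a number 2.2 percentage points lower from compound 3 to compound 4 (within the scatter) is none beyond the scatter. Compound 4 is therefore estimated to give 47% in this assay, in a range from 35% to 59%.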

Compound 4, a percentage reported as activity, at one concentration (the size of the read-out at that concentration, not a potency): 54.3%
For compound 4 the middle estimate is 7.3 percentage points below the measured one, within the range that was stated.
By their numbers in this assay, from the lowest: compounds 2, 1, 3 and 4 (each within the scatter of the next, the first and the last beyond it).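

Replacing the hydroxy with methoxy gives a number 5.1 percentage points higher from compound 3 to compound 4 (within the scatter) in this assay, so in this pair the hydrogen on that oxygen can be swapped for methyl without moving the read-out beyond the usual scatter. For the compounds shown here, this is the first direct reading of the change at this oxygen. By contrast, trifluoromethyl in place of hydrogen on an aromatic carbon gives a number 17 percentage points higher from compound 2 to compound 4 (beyond the scatter). A higher number means a weaker effect here. The added trifluoromethyl is the only single change shown that weakens the effect beyond the scatter.

As far as these compounds go, how an amine or a longer chain such as ethoxy would behave in place of the methoxy remains open. The reason for either step is open too, as no measurement shown bears on a cause.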